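The source may hold more compounds than are shown below. What is called first, only, known or untested is meant among the compounds shown, and "the series" means these compounds.

Working notes on the series. In a functional assay on DU-145 cells (Homo sapiens) for cytotoxicity, read by MTT assay (on this read-out lower numbers stand for stronger inhibition and higher numbers for weaker inhibition), compound 1 `CC(C)=CC[C@@H](OC(=O)CC(O)c1ccccc1)C1=CC(=O)c2c(O)ccc(O)c2C1=O` gives 17000 nM and compound 2 `CCC(CO[C@H](CC=C(C)C)C1=CC(=O)c2c(O)ccc(O)c2C1=O)OC(C)=O` gives 25400 nM on the shared core. Among the measured compounds shown here, these two values lie within the scatter of each other, so compound 2 stands level with compound 1 on the numbers so far. Compound 3 `CC(C)=CC[C@@H](OC(=O)C1CCCO1)C1=CC(=O)c2c(O)ccc(O)c2C1=O` is the next to be read. Its difference from compound 2 is (oxolan-2-yl)carbonyl in place of 2-acetoxybutyl on an oxygen on a saturated carbon in all: (oxolan-2-yl)carbonyl in place of 2-acetoxybutyl on an oxygen on a saturated carbon. For the measured compounds named here, no measured pair differs in one place, so the data hold no direct guide to this change. With only these two values to go on, no shift beyond the scatter is expected in this assay in either direction. The estimated move, a 1.4-fold lower number from compound 2 to compound 3 (0.15 log units; within the scatter) as a central figure, stays inside the scatter. For compound 3 the estimated value is 18000 nM within an expected range of 6000 nM to 45000 nM on this read-out.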

Compound 3, half-maximal inhibitory concentration: 10500 nM
The estimate for compound 3 lay 1.7-fold (0.23 log units) above the measured number; measured number inside the range.
By their numbers in this assay, from the lowest: compounds 3, 1 and 2 (each within the scatter of the next, the first and the last beyond it).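

In this assay, among the compounds shown here, the change from 2-acetoxybutyl to (oxolan-2-yl)carbonyl on an oxygen on a saturated carbon gives a 2.4-fold lower number from compound 2 to compound 3 (0.38 log units; beyond the scatter), the first step to pass the scatter, though only modestly. The change brings in one five-membered non-aromatic ring, while the counts of hydrogen-bond donors and acceptors stay the same. Oxolan-2-yl in place of 2-hydroxy-2-phenylethyl on a carbonyl carbon gives a 1.6-fold lower number from compound 1 to compound 3 (0.21 log units; within the scatter), so this second change sets no order between its two compounds, and no measurement at hand accounts for either step.

The ring and the carbonyl enter together in compound 3, so their shares in the step remain unresolved. A plain acetyl group on that oxygen would separate them, and an amine on the ring would test how far the position accepts a different group.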